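Benzyl in place of phenyl on the amide-type nitrogen

The compounds below may be only part of what the source reports. "The series", "measured", "known", "first", "only" and "open" are said of these compounds alone.

Measured compounds, with their values in a functional assay on MCF7 cells (Homo sapiens) for cytotoxicity, read by MTT assay; a lower number here means a stronger inhibitor, a higher number a weaker inhibitor:

compound 1 `CC(C)C[C@@H](NC(=S)Nc1ccccc1)c1nc2ccccc2[nH]1` gives 11900 nM
compound 2 `CC(C)C[C@H](NC(=S)Nc1ccccc1)c1nc2ccccc2[nH]1` gives 25800 nM
compound 3 `C[C@@H](NC(=S)Nc1ccccc1)c1nc2ccccc2[nH]1` gives 16400 nM

Compound 1 holds the lowest number of the three. Compound 3 sits within the scatter of it, while compound 2 lies beyond it: a 2.2-fold higher number from compound 1 to compound 2 (0.34 log units; beyond the scatter), a step that rests only on (the fact that compounds 1 and 2 differ only in the configuration as drawn). The other measured step, a 1.4-fold higher number from compound 1 to compound 3 (0.14 log units; within the scatter), removes the isopropyl from the saturated chain carbon and stays within the scatter.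

Compound 4 `CC(C)C[C@@H](NC(=S)NCc1ccccc1)c1nc2ccccc2[nH]1` keeps the configuration and the side chain of compound 1 and differs from it only in benzyl in place of phenyl on an amide-type nitrogen. Going by the values given here, neither measured step touches the amide-type nitrogen or its substituent, so neither bears directly on this change; the one step of comparable kind, a change of group on the chain carbon, was within the scatter. The expectation is therefore no step beyond the scatter in this assay, a 1.0-fold higher number from compound 1 to compound 4 (0.00 log units; within the scatter), with wider uncertainty than for a measured step. Compound 4 is estimated at 12000 nM, expected between 5000 nM and 30000 nM.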

Compound 4, half-maximal inhibitory concentration: 18200 nM
Beside the measured number, compound 4's estimate is 1.5-fold (0.18 log units) below it; the measured number falls inside the stated range.
By their numbers in this assay, from the lowest: compounds 1, 3, 4 and 2 (each within the scatter of the next, the first and the last beyond it).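

In this assay, going by these compounds alone, the step of a 1.5-fold higher number from compound 1 to compound 4 (0.18 log units; within the scatter) is the first reading of any change on the amide-type nitrogen, since the earlier steps touched only the saturated chain carbon. With the side chain and configuration of compound 1 held fixed, the anilino to benzylamino change stays within the scatter, so this position accepts benzyl in place of phenyl without a readable shift in this assay. No available evidence bears on this change.

Open, from the compounds shown here alone, is whether that holds for a longer chain on the nitrogen, such as phenethyl, or for a ring carrying an amine or a carboxylic acid. Also open, going by these compounds, is whether the configuration step a 2.2-fold higher number from compound 1 to compound 2 (0.34 log units; beyond the scatter) recurs when benzyl sits on the nitrogen.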